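Removing the second methoxy group in the series

A few compounds are considered here, and "the series" means these few. Any claim that something is new, unique, unknown or untested is made for them only; others in the source may bear on it.

Compound 1 `Nc1cc(N)c2nc(-c3ccccc3)c(Sc3ccc(F)cc3)nc2c1` carries the shared core of the series. In a functional assay on ACHN cells (Homo sapiens) for inhibition, read by sulforhodamine B assay, with a stated time of 48 h (on this read-out lower numbers stand for higher toxicity in this test and higher numbers for lower toxicity in this test), compound 1 gives only a limit of < 100000 nM, not a number. Compound 2 `COc1cc(CNc2nc3cc(N)cc(N)c3nc2-c2ccccc2)cc(OC)c1OC` gives 23400 nM in this assay, and compound 3 `COc1ccc(CNc2nc3cc(N)cc(N)c3nc2-c2ccccc2)cc1OC` gives 81300 nM in this assay. Among the measured compounds shown here, compound 3 thus holds the highest of the two numbers known so far; the single measured step is a 3.5-fold higher number from compound 2 to compound 3 (0.54 log units; beyond the scatter). Compound 4 `COc1ccc(CNc2nc3cc(N)cc(N)c3nc2-c2ccccc2)cc1` is not yet measured. It differs from compound 3 by hydrogen in place of methoxy on an aromatic carbon. For the measured compounds named here, the one measured step that bears on this change, a 3.5-fold higher number from compound 2 to compound 3 (0.54 log units; beyond the scatter), is of the same kind, hydrogen in place of methoxy on an aromatic carbon, and it moved the number upward beyond the scatter. A further move in the same direction is therefore expected for compound 4, of comparable or somewhat smaller size, a 2.2-fold higher number from compound 3 to compound 4 (0.35 log units; beyond the scatter). Compound 4 is expected to give about 180000 nM in this assay, within a range of 70000 nM to 450000 nM. There is a fair chance that compound 4 is reported only as a limit in this assay.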

Compound 4, concentration lethal to 50% of the cells: 75900 nM
For compound 4 the middle estimate is 2.4-fold (0.38 log units) above the measured one; the measured number falls inside the stated range.
By their numbers in this assay, from the lowest: compound 2; then compounds 4 and 3 (each within the scatter of the next).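

Going from 3,4-dimethoxyphenyl to 4-methoxyphenyl gives a 1.1-fold lower number from compound 3 to compound 4 (0.03 log units; within the scatter) in this assay. The earlier step of the same kind, a 3.5-fold higher number from compound 2 to compound 3 (0.54 log units; beyond the scatter), thus does not carry over to this place: here, ortho to a methoxy group and meta to a large group, hydrogen and methoxy cannot be told apart in this read-out, so the effect of replacing methoxy by hydrogen depends on where on the ring it is made. Compound 1 stands only as a limit and not as a number, so it takes no part in this comparison: the limit of < 100000 nM in this assay, at which 1 of the 4 values shown sits.

On these data alone, what a hydroxyl, an amine or a chlorine atom at this place would give stays open. Also open is what the remaining methoxy group of the 4-methoxyphenyl contributes, since no compound shown replaces it with hydrogen.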